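This account rests on a few compounds, and the source may have more. Where it says the series, first, only, none or still open, it means among the compounds named here.

Of the compounds shown here, two that share one core have been measured so far. In a functional assay (strain AB) with Danio rerio as the target, read by microscopy, with a stated time of 1 h (a lower number here means that less compound is needed, a higher number that more compound is needed for the effect), compound 1 (`NC(=O)c1c(NC(=O)Nc2ccc(Cl)cc2)sc2c1CCN(CC1CCC1)C2`) gives 1360 nM and compound 2 (`CC(C)N1CCc2c(sc(NC(=O)Nc3ccc(Cl)cc3)c2C(N)=O)C1`) gives 1490 nM. The measured step, a 1.1-fold higher number from compound 1 to compound 2 (0.04 log units; within the scatter), lies within the scatter, so compound 2 stands level with compound 1. Compound 3 (`CC(C)(C)OC(=O)CCCN1CCc2c(sc(NC(=O)Nc3ccc(Cl)cc3)c2C(N)=O)C1`) keeps the core of compound 2 and differs in one place: 3-(tert-butoxycarbonyl)propyl in place of isopropyl on an amine nitrogen in a ring. Going by the values given here, the step to compound 2 is the only evidence for a change at this amine nitrogen, and it involved a different pair of groups. Among the compounds with values here, no measured compound carries a tert-butoxycarbonyl group, so the direction of any shift remains open. No clear move in this assay is therefore expected, though the uncertainty is wide. The expected step is a 1.1-fold higher number from compound 2 to compound 3 (0.06 log units; within the scatter). Compound 3 is estimated at 1700 nM, with an expected range from 500 nM to 5000 nM.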

Compound 3, half-maximal effective concentration: 560 nM
Compound 3: middle estimate off by 3.0-fold (0.48 log units), on the high side, and the stated range covers the measured number.
By their numbers in this assay, from the lowest: compound 3; then compounds 1 and 2 (each within the scatter of the next).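

In this assay, the amine nitrogen in the ring now responds to a change of group: there is a 2.7-fold lower number from compound 2 to compound 3 (0.42 log units; beyond the scatter), and also a 2.4-fold lower number from compound 1 to compound 3 (0.39 log units; beyond the scatter). Exchanging isopropyl and cyclobutylmethyl had moved nothing beyond the scatter, whereas the 3-(tert-butoxycarbonyl)propyl chain shows that this position can tolerate a much larger group and still give a modestly lower number. Nothing measured here accounts for this shift.

The compounds shown leave open which part of the entering group goes with the lower number, the chain or the tert-butoxycarbonyl end. A plain pentyl chain, the matching carboxylic acid or a primary amide at the chain end would separate these possibilities, and a longer chain would show whether the trend continues.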